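The source may report more compounds than this note shows. Statements on the series, on what has been measured and on what is new or still open speak of the compounds shown alone.

Compound 3 `CCC/C=C/c1nc2c(c(=O)n(C)c(=O)n2C)n1C` sits second highest among the three numbers in an assay for binding affinity to adenosine receptor A1 (Rattus norvegicus), read by radioligand binding; a higher number here means a weaker inhibitor, a lower number a stronger inhibitor: compound 3 gives 9100 nM, compound 2 `Cn1c(=O)c2c(nc(C3CCC3)n2C)n(C)c1=O` gives 30000 nM, and compound 1 `CCC/C=C/c1nc2c(=O)n(C)c(=O)n(C)c2[nH]1` gives 380 nM. Going by the values given here, the only single-place step between measured compounds is a 3.3-fold lower number from compound 2 to compound 3 (0.52 log units; beyond the scatter). Among the compounds with values here, no step is computed for compound 1 against compound 3; the two values only show that compound 1 lies well under compound 3.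

Compound 4 `Cn1c(=O)c2c(nc(/C=C/C(=O)OC(C)(C)C)n2C)n(C)c1=O` carries tert-butoxycarbonyl in place of propyl on a double-bonded chain carbon bound to a double-bonded chain carbon. Within the data shown here, none of the measured steps alters the end of the pent-1-en-1-yl chain; the step from compound 2 to compound 3 concerns the same aromatic carbon but exchanges the whole substituent, so it bears on this change only loosely and gives no direction. With nothing pointing one way, the expectation for compound 4 in this assay is a step of a 1.6-fold higher number from compound 3 to compound 4 (0.22 log units; within the scatter), within the scatter or a little beyond it, and the range is kept wide in both directions. Compound 4 is estimated at 15000 nM, from 3000 nM to 60000 nM.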

Compound 4, inhibition constant: 12000 nM
Compound 4: the middle estimate sits 1.3-fold (0.10 log units) above what was measured; measured number inside the range.
By their numbers in this assay, from the lowest: compound 1; then compounds 3 and 4 (each within the scatter of the next); then compound 2.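

In this assay the chain end can now be read on its own, apart from the whole-substituent exchange of the earlier step: tert-butoxycarbonyl in place of propyl gives a 1.3-fold higher number from compound 3 to compound 4 (0.12 log units; within the scatter). Within this single pair, then, a larger, oxygen-bearing group with hydrogen-bond acceptors at this place on a double-bonded chain carbon bound to a double-bonded chain carbon leaves the number within the scatter, though one pair fixes no trend for the position. No measurement available here accounts for this result.

Open, on these data alone, is whether a carboxylic acid, a primary amide or a longer alkyl chain at the same place would also stay within the scatter of compound 3. Also open, as far as these compounds go, is how tert-butoxycarbonyl would read on the core of compound 1, which gives 380 nM with propyl at this place.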